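Chloro to Fluoro on the Benzyl Group of Compound 2

The source may report more compounds than this note shows. Statements on the series, on what has been measured and on what is new or still open speak of the compounds shown alone.

Measured so far:
- compound 1 `O=C1N=C(Nc2ccc(F)c(Cl)c2)S/C1=C\c1ccc(-c2ccc(C(=O)O)c(O)c2)o1`: 13000 nM
- compound 2 `O=C1/C(=C/c2ccc(-c3cc(C(F)(F)F)ccc3Cl)o2)SC(=S)N1Cc1ccc(Cl)cc1`: 1130 nM

Both compounds were tested in a functional assay on MCF7 cells (Homo sapiens) for inhibition, read by MTT assay, with a stated time of 2 days; a higher number here means a weaker inhibitor, a lower number a stronger inhibitor. Of the two numbers, compound 2 gives the lower one with 1130 nM, while compound 1 gives 13000 nM; the gap between them is beyond the usual scatter, so compound 2 is the stronger inhibitor of the pair. The two structures differ in several places at once, so no single change can be tied to that gap.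

Compound 3 `O=C1/C(=C/c2ccc(-c3cc(C(F)(F)F)ccc3Cl)o2)SC(=S)N1Cc1ccc(F)cc1` keeps the whole of compound 2 except for one change: fluoro in place of chloro on an aromatic carbon. For the measured compounds named here, no measured pair shows this exact swap, so the expectation rests on the size of the change alone, which is small. The step from compound 2 to compound 3 in this assay is expected to be modest, a 1.4-fold higher number from compound 2 to compound 3 (0.15 log units; within the scatter), likely a slight weakening but possibly within the scatter. Compound 3 is therefore estimated at 1600 nM, with a range from 600 nM to 4500 nM.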

Compound 3, half-maximal inhibitory concentration: 1200 nM
Beside the measured number, compound 3's estimate is 1.3-fold (0.12 log units) above it; low and high end bracket the measured number.
By their numbers in this assay, from the lowest: compounds 2 and 3 (each within the scatter of the next); then compound 1.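

This is the first step among the compounds shown that changes only one place, so it can be tied to a single swap: 4-chlorobenzyl to 4-fluorobenzyl gives a 1.1-fold higher number from compound 2 to compound 3 (0.03 log units; within the scatter) in this assay. On this aromatic carbon, para to a large group, chloro and fluoro therefore cannot be told apart in this assay, and either halogen serves equally well as far as this read-out can show. Nothing on hand explains why the two read alike.

Open, going by these compounds, is whether this tolerance extends to groups of a different kind at the same carbon, such as an amine, a methoxy group or a plain hydrogen. Also open, on these data alone, is whether the chloro on the other aromatic ring, or the trifluoromethyl group there, can be exchanged just as freely.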